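The source may hold more compounds than are shown below. What is called first, only, known or untested is meant among the compounds shown, and "the series" means these compounds.

Within the data shown here, in an ADME assay on HFF cells (Homo sapiens) for cytotoxicity, read by MTT assay, with a stated time of 72 h (a lower number here means a stronger inhibitor, a higher number a weaker inhibitor), compound 1 `O=C1O[C@H]([C@@H](O)Cn2cc(-c3ccc(Br)cc3)nn2)C(OCc2ccccc2)=C1OCc1ccccc1` gives 5100 nM, the only true number among the three compounds measured so far. Compound 2 `O=C1O/C(=C\Cn2cc(-c3cc(C(F)(F)F)cc(C(F)(F)F)c3)nn2)C(OCc2ccccc2)=C1OCc1ccccc1` reads > 100000 nM, which is a limit of the assay and not a number. Compound 3 `COc1ccc(-c2cn(C/C=C3\OC(=O)C(OCc4ccccc4)=C3OCc3ccccc3)nn2)cc1` reads > 100000 nM, and this too is a limit.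

The next compound, compound 4 `CC(C)(C)c1cn(C[C@H](O)[C@H]2OC(=O)C(OCc3ccccc3)=C2OCc2ccccc2)nn1`, keeps the core of compound 1 and changes one group: tert-butyl in place of 4-bromophenyl on an aromatic carbon. In words, tert-butyl stands in place of 4-bromophenyl on an aromatic carbon of the five-membered aromatic ring with 3 nitrogen. Among the measured compounds shown here, no two measured compounds differ in one place only, so nothing measured yet shows what this swap does by itself.

In this assay, the expected change is a 2.9-fold higher number from compound 1 to compound 4 (0.47 log units; beyond the scatter), towards a weaker reading, and this is a loose expectation resting on a single number. For compound 4 the estimated value is 15000 nM, with an expected range from 4000 nM to 80000 nM.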

Compound 4, half-maximal inhibitory concentration: 13300 nM
Beside the measured number, compound 4's estimate is 1.1-fold (0.05 log units) above it; the range from low to high includes it.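

In this assay, among these compounds, this is the first change at this position that can be read on its own: tert-butyl in place of 4-bromophenyl on an aromatic carbon gives a 2.6-fold higher number from compound 1 to compound 4 (0.42 log units; beyond the scatter), a modest step towards a weaker reading. A measurable reading therefore survives when the six-membered aromatic ring at this place is replaced by a group with no ring. Compound 4 also gives a true number, so it can be compared directly with compound 1 and does not stop at the assay's limit: the limit of > 100000 nM in this assay, at which 2 of the 4 values shown sit.

Among the compounds shown here, compound 2 and compound 3 differ from compound 1 in more than one place, so no step to either can be read. The compounds shown also leave open how an amine or a carboxylic acid on this aromatic carbon would read.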